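Notes on the ring amine of the shared core

The source may report more compounds than this note shows. Statements on the series, on what has been measured and on what is new or still open speak of the compounds shown alone.

Among the measured compounds shown here, compound 2 `CC(=O)OC1CCN(c2nc(C(F)(F)F)ccc2CNC(=O)C(C)c2ccc(NS(C)(=O)=O)c(F)c2)CC1` gives 139 nM in a functional assay on CHO-K1 cells for antagonist activity at transient receptor potential cation channel subfamily V member 1 (Homo sapiens), read by FLIPR (a higher number here means a weaker inhibitor, a lower number a stronger inhibitor), and stands as the lowest of the two numbers measured so far. Its nearest neighbour is compound 1 `CC(C(=O)NCc1ccc(C(F)(F)F)nc1Nc1ccccc1)c1ccc(NS(C)(=O)=O)c(F)c1`, which in this assay gives 1400 nM; the step from compound 1 to compound 2 was a 10-fold lower number from compound 1 to compound 2 (1.00 log units; beyond the scatter), 4-acetoxypiperidin-1-yl in place of anilino on an aromatic carbon.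

Compound 3 `CC(C(=O)NCc1ccc(C(F)(F)F)nc1N1CCCCCCC1)c1ccc(NS(C)(=O)=O)c(F)c1` is not yet measured. It differs from compound 2 by a group of 8 heavy atoms (7 carbon, 1 nitrogen; one eight-membered non-aromatic ring with 1 hetero atom) in place of a group of 10 heavy atoms (7 carbon, 1 nitrogen, 2 oxygen; one six-membered non-aromatic ring with 1 hetero atom), on an aromatic carbon. For the measured compounds named here, no measured step tries this exchange directly. Going by the values given here, the only measured step, a 10-fold lower number from compound 1 to compound 2 (1.00 log units; beyond the scatter), replaced anilino with 4-acetoxypiperidin-1-yl and shows that the substituent at this aromatic carbon moves the number strongly, but it says nothing about what the entering eight-membered ring does relative to the leaving six-membered one. The expectation for compound 3 is therefore a step of a 1.6-fold higher number from compound 2 to compound 3 (0.20 log units; within the scatter), placed close to no change and given a wide range. Compound 3 is expected at 220 nM in this assay, estimated to fall between 50 nM and 900 nM.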

Compound 3, half-maximal inhibitory concentration: 27.8 nM
The estimate for compound 3 lay 7.9-fold (0.90 log units) above the measured number; measured number below the stated range.
By their numbers in this assay, from the lowest: compound 3; then compound 2; then compound 1.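

In this assay, the position on the aromatic carbon next to the ring nitrogen tolerates a larger ring than the piperidine of compound 2: the eight-membered non-aromatic ring, which carries no further substituent, gives a 5.0-fold lower number from compound 2 to compound 3 (0.70 log units; beyond the scatter). The acetoxy group is therefore not needed for a low number among these compounds, and compound 3 now holds the lowest number of the three, with steps to both others beyond the scatter. Against the anilino group of compound 1, the same ring gives a 50-fold lower number from compound 1 to compound 3 (1.70 log units; beyond the scatter), so both non-aromatic ring amines shown lie below anilino, with no compound here going against that order, and no measurement at hand bears on the reason for the order.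

The step from compound 2 to compound 3 changes ring size and removes the acetoxy group at once, so the share of each in the change cannot be separated. On these data alone, whether unsubstituted piperidin-1-yl would fall nearer compound 2 or compound 3 stays open, as does the effect of azepan-1-yl, an intermediate ring size, or of morpholin-4-yl, which adds a ring oxygen.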